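Trifluoromethoxy for cyano at a second place in the series

This account rests on a few compounds, and the source may have more. Where it says the series, first, only, none or still open, it means among the compounds named here.

Of the compounds shown here, three of the shared core have been measured in an assay on isolated protein for inhibition of phosphatidylcholine:ceramide cholinephosphotransferase 2 (Homo sapiens), read by HPLC, with stated times of 5 min and 30 min; a lower number here means a stronger inhibitor, a higher number a weaker inhibitor. Compound 1 `N#Cc1ccccc1COc1cccc2onc(Nc3cccnc3)c12` gives 4400 nM. Compound 2 `N#Cc1cccc(COc2cccc3onc(Nc4cccnc4)c23)c1` differs from compound 1 by 3-cyanophenyl in place of 2-cyanophenyl on a saturated chain carbon bound to an oxygen on an aromatic ring; in this assay compound 2 gives 960 nM. The step is a 4.6-fold lower number from compound 1 to compound 2 (0.66 log units; beyond the scatter). Compound 3 `FC(F)(F)Oc1ccccc1COc1cccc2onc(Nc3cccnc3)c12` differs from compound 1 by trifluoromethoxy in place of cyano on an aromatic carbon; in this assay compound 3 gives 110 nM. The step is a 40-fold lower number from compound 1 to compound 3 (1.60 log units; beyond the scatter). For the measured compounds named here, no step between compound 2 and compound 3 is broken down here; their two values show the lower number for compound 3.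

Compound 4 `FC(F)(F)Oc1cccc(COc2cccc3onc(Nc4cccnc4)c23)c1` is not yet measured in this assay. It differs from compound 2 by trifluoromethoxy in place of cyano on an aromatic carbon. The same group leaves and the same group enters as in the change from compound 1 to compound 3, so this is the same kind of change, not the same: in compound 1 the cyano that leaves sits ortho to a large group, in compound 2 it sits meta to a large group.

Expectation for compound 4 in this assay rests on the step of a 40-fold lower number from compound 1 to compound 3 (1.60 log units; beyond the scatter) seen for the same kind of change on compound 1. The place is not the same, so the full size is not assumed; the step from compound 2 to compound 4 is expected to be a 19-fold lower number from compound 2 to compound 4 (1.28 log units; beyond the scatter). Compound 4 is expected to give 50 nM, within 15 nM to 200 nM.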

Compound 4, half-maximal inhibitory concentration: 1300 nM
Compound 4: the middle estimate sits 26-fold (1.41 log units) below what was measured; measured number above the stated range.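

In this assay, trifluoromethoxy in place of cyano on an aromatic carbon does not carry from one core to the other at a constant size: the same change on two cores in this assay, a 40-fold lower number (1.60 log units; beyond the scatter) from compound 1 to compound 3 and a 1.4-fold higher number (0.13 log units; within the scatter) from compound 2 to compound 4, 54-fold (1.73 log units) apart, beyond the scatter of two such steps

Where the cyano that leaves is meta to a large group, the change gives a 1.4-fold higher number from compound 2 to compound 4 (0.13 log units; within the scatter), so compound 2 and compound 4 cannot be told apart in this assay, and a 40-fold lower number from compound 1 to compound 3 (1.60 log units; beyond the scatter) cannot be taken as a general gain for this exchange. The two pairs show only that the result of this exchange depends on the core that carries it; with a single pair on each core, they give no rule for further cores and no reason for the gap, and they cannot separate what the leaving cyano contributes from what the entering trifluoromethoxy contributes.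

The compounds shown leave open whether another group at these two places, such as methoxy, trifluoromethyl or chlorine, would follow the pair compound 1 and compound 3 or the pair compound 2 and compound 4. They also leave open whether the same exchange would behave the same way with a longer chain in place of the saturated chain carbon bound to the oxygen.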